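The source may hold more compounds than are shown below. What is called first, only, known or untested is meant among the compounds shown, and "the series" means these compounds.

Working notes on the series. Among the compounds with values here, compound 2 `CN(C)c1ncnc2c1ncn2C` gives 30% in a functional assay on the whole organism for inhibition, with Rattus norvegicus as the target, at a dose of 25 mg/kg by the intraperitoneal route (on this read-out lower numbers stand for less inhibition and higher numbers for more inhibition at the one dose given (going by the name of the read-out)), the higher of the two numbers so far; compound 1 `CN(C)c1ncnc2c1ncn2CC1CCCCC1` gives 0% in this assay. Within the data shown here, the one step in hand, a number 30 percentage points higher from compound 1 to compound 2 (beyond the scatter), runs from the larger group at that carbon to the smaller one and goes up. Compound 3 `CCCCCn1cnc2c(N(C)C)ncnc21` is not yet measured in this assay. The change from compound 2 to compound 3 is butyl in place of hydrogen on a saturated chain carbon bound to an aromatic nitrogen. The step from compound 1 to compound 2 is the only one that bears on it: it shows that removing a ring-bearing group from this carbon raised the number, and compound 3 goes the other way by adding a chain without a ring, a smaller addition than the cyclohexyl that was removed. The expected step is therefore downward, and a number 15 percentage points lower from compound 2 to compound 3 (beyond the scatter) is the estimate for compound 3 in this assay, smaller than the step from compound 1 to compound 2. The estimate for compound 3 in this assay is 15%, with a range from 0% to 35%.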

Compound 3, a percentage reported as inhibition, in the whole organism at one dose (the size of the read-out at that dose, not a potency): 0%
Estimate against measurement, compound 3: 15 percentage points above, within the range that was stated.
By their numbers in this assay, from the lowest: compounds 1 and 3 (each within the scatter of the next); then compound 2.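

In this assay, butyl in place of hydrogen on a saturated chain carbon bound to an aromatic nitrogen gives a number 30 percentage points lower from compound 2 to compound 3 (beyond the scatter), so the fall in inhibition on enlarging the group at this carbon does not depend on a ring in the entering group. Butyl in place of cyclohexyl at the same carbon gives no change at the digits printed from compound 1 to compound 3 (within the scatter), and with compound 1 at 0% and compound 3 at 0%, this read-out at its one dose does not tell the two groups apart. Among the three compounds, only compound 2, with the smallest group at this carbon, shows inhibition, and its steps to both others lie beyond the scatter. No measurement in hand gives a reason for this drop.

On these data alone, whether an ethyl or propyl chain in place of the methyl of compound 2 keeps any of its inhibition remains open, as does the outcome for a chain ending in an amine or a carboxylic acid. Also open, as far as these compounds go, is how compound 1 and compound 3 would compare at a higher dose, where inhibition might separate them.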